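Amine swap at the quinoline-adjacent position: from bicycle to aminopyrrolidine

A few compounds are considered here, and "the series" means these few. Any claim that something is new, unique, unknown or untested is made for them only; others in the source may bear on it.

Three amides sharing one core have been measured in a functional assay on HEK293 cells for activation of melanin-concentrating hormone receptor 1 (Rattus norvegicus), read by inositol phosphate accumulation; on this read-out lower numbers stand for an effect already at smaller amounts and higher numbers for an effect only at larger amounts of compound. Compound 1 `CN(c1ccc2cc(NC(=O)CCc3ccc(C(F)(F)F)cc3)ccc2n1)C1CCCC1` gives 350 nM. Compound 2 `O=C(CCc1ccc(C(F)(F)F)cc1)Nc1ccc2nc(N3CCCC3)ccc2c1` gives 320 nM; 320 nM (2 entries) in two entries. Compound 3 `O=C(CCc1ccc(C(F)(F)F)cc1)Nc1ccc2nc(N3CC4CCC3CC4)ccc2c1` gives 190 nM. Compound 3 thus carries the lowest number among the measured compounds, but the step of a 1.8-fold lower number from compound 1 to compound 3 (0.27 log units; within the scatter) shows that this gap to compound 1 does not exceed the scatter, and the two entries for compound 2 sit in the same band, so the three compounds cannot be told apart on this read-out.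

Compound 4 `NC1CCN(c2ccc3cc(NC(=O)CCc4ccc(C(F)(F)F)cc4)ccc3n2)C1` is not yet measured. It differs from compound 3 by a group of 6 heavy atoms (4 carbon, 2 nitrogen; one five-membered non-aromatic ring with 1 hetero atom) in place of a group of 8 heavy atoms (7 carbon, 1 nitrogen; 2 six-membered non-aromatic rings with 1 hetero atom each), on an aromatic carbon. For the measured compounds named here, the only measured step that bears on the same position is that from compound 1 to compound 3, which is within the scatter, and the pyrrolidinyl compound 2 sits alongside both. Going by the values given here, every amine tried at this position so far has returned a number in one narrow band, so no shift beyond the scatter is expected for this assay, while the new hydrogen-bond donor leaves the outcome less certain than the earlier swaps.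

The expected step is a 1.6-fold higher number from compound 3 to compound 4 (0.20 log units; within the scatter). Compound 4 is therefore estimated at 300 nM, with a range from 90 nM to 1000 nM.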

Compound 4, half-maximal effective concentration: 200 nM
Compound 4: middle estimate off by 1.5-fold (0.18 log units), on the high side; low and high end bracket the measured number.
By their numbers in this assay, from the lowest: compounds 3, 4 and 1 (each within the scatter of the next).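

In this assay, the change to 3-aminopyrrolidin-1-yl is the first shown in which the entering group has 1 hydrogen-bond donor where the leaving group has 0, and its size also falls from 8 heavy atoms to 6, yet the result is a 1.1-fold higher number from compound 3 to compound 4 (0.02 log units; within the scatter). Set against the open-chain amine of the series, the same group gives a 1.8-fold lower number from compound 1 to compound 4 (0.24 log units; within the scatter), so on an aromatic carbon next to the ring nitrogen, a primary amine on the ring now joins the tertiary amines in one band, and neither the added nitrogen nor the smaller ring separates compound 4 from compound 3 or compound 1. No measurement at hand says why the number stays put through this change.

What the compounds shown leave open is whether any group at this place can move the number beyond the scatter, such as a carboxylic acid on the pyrrolidine ring or a longer chain ending in an amine. They also leave open whether the rest of the molecule responds more sharply, for instance a nitrile in place of the trifluoromethyl group, or a longer chain between the carbonyl and the aromatic ring.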